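Compound 3: 4-methylphenyl on the shared core

This account rests on a few compounds, and the source may have more. Where it says the series, first, only, none or still open, it means among the compounds named here.

Among the measured compounds shown here, in a functional assay on MCF7 cells (Homo sapiens) for antiproliferative activity, read by MTT assay, with a stated time of 48 h (a higher number here means a weaker inhibitor, a lower number a stronger inhibitor), compound 1 (`CC(=O)N1N=C(c2ccc3ccccc3c2)OC1c1ccccc1Br`) gives 5.49 ug/mL and compound 2 (`CC(=O)N1N=C(c2ccc3ccccc3c2)OC1c1ccncc1`) gives 2.56 ug/mL as the lower of the two numbers so far. The gap between them is beyond the scatter but modest. Compound 3 (`CC(=O)N1N=C(c2ccc3ccccc3c2)OC1c1ccc(C)cc1`) carries 4-methylphenyl in place of pyridin-4-yl on a saturated ring carbon.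

For the measured compounds named here, only one measured step bears on this change: a 2.1-fold lower number from compound 1 to compound 2 (0.33 log units; beyond the scatter) with pyridin-4-yl in place of 2-bromophenyl at the same ring carbon. Going by the values given here, the entering group in compound 3 is also a six-membered aromatic ring of carbon only, as in compound 1, but no measured compound carries 4-methylphenyl, so this comparison is loose. With compound 1 at 5.49 ug/mL as the sole reference with such a ring, a modest step toward a higher number is expected in this assay and it may stay within the scatter. This expectation corresponds to a 1.6-fold higher number from compound 2 to compound 3 (0.22 log units; within the scatter) as an estimated step. Compound 3 is expected at 4.2 ug/mL (estimated range 1.9 ug/mL to 9.5 ug/mL).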

Compound 3, half-maximal inhibitory concentration: 2.9 ug/mL
The estimate for compound 3 lay 1.4-fold (0.16 log units) above the measured number; measured number inside the range.
By their numbers in this assay, from the lowest: compounds 2, 3 and 1 (each within the scatter of the next, the first and the last beyond it).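

Working notes on this position: in this assay the ring nitrogen of pyridin-4-yl is not needed to hold the number on this saturated ring carbon, since the step to 4-methylphenyl, an all-carbon ring with no hydrogen-bond acceptor, gives a 1.1-fold higher number from compound 2 to compound 3 (0.05 log units; within the scatter). An all-carbon ring at this place therefore does not by itself go with the number of compound 1: the step is a 1.9-fold lower number from compound 1 to compound 3 (0.28 log units; within the scatter), so compound 3 lies within the scatter of both compound 1 and compound 2, and only those two are separated beyond it. No measured data on the compounds bear on what lies behind these steps.

Compound 1 and compound 3 differ both in the group on the phenyl ring and in where it sits, so these compounds cannot separate the bromo group from its place on the ring. Also open, from the compounds shown here alone, is whether an amine or a carboxylic acid in place of the methyl of 4-methylphenyl, or a longer chain there, would stay within the scatter of compound 3 in this assay.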